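The source may hold more compounds than are shown below. What is called first, only, known or untested is meant among the compounds shown, and "the series" means these compounds.

Working notes on the series. Three compounds share one core, carrying different aryl groups on an aromatic carbon: compound 1 `COc1ccc(C(=O)O)cc1-c1cccc(COc2ccc3c(c2)CN(C2CCCC2)C3=O)c1`, compound 2 `O=C(O)c1cc(-c2cccc(COc3ccc4c(c3)CN(C3CCCC3)C4=O)c2)ccc1O` and compound 3 `O=C(O)c1ccc(Cl)c(-c2cccc(COc3ccc4c(c3)CN(C3CCCC3)C4=O)c2)c1`. In an assay on HEK293 cells for positive allosteric modulation of metabotropic glutamate receptor 2 (Rattus norvegicus), read by thallium flux (on this read-out higher numbers stand for larger maximal responses and lower numbers for smaller maximal responses), compound 1 gives 79.2%, compound 2 gives 90.1% and compound 3 gives 93.9%. Compound 3 shows the highest of the three numbers; its nearest neighbour is compound 2, with the step of a number 3.8 percentage points higher from compound 2 to compound 3 (within the scatter), while the largest gap is the step of a number 14.7 percentage points higher from compound 1 to compound 3 (beyond the scatter). The remaining step is a number 10.9 percentage points higher from compound 1 to compound 2 (beyond the scatter).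

The next compound, compound 4 `COc1ccc(-c2cccc(COc3ccc4c(c3)CN(C3CCCC3)C4=O)c2)cc1C(=O)O`, is not yet measured. It differs from compound 3 as follows: 3-carboxy-4-methoxyphenyl in place of 5-carboxy-2-chlorophenyl on an aromatic carbon. Within the data shown here, two measured steps bear on this. The step from compound 1 to compound 3 shows that the methoxy-bearing aryl sits lowest in this assay, and the step from compound 1 to compound 2 shows that the 3-carboxy-4-hydroxyphenyl pattern, which compound 4 shares apart from methoxy in place of hydroxy, runs higher. Compound 4 therefore combines a pattern that pulled upward with a group that sat lowest; the expected step is a number 9.9 percentage points lower from compound 3 to compound 4 (within the scatter), downward and modest, likely near the edge of the scatter. The estimate for compound 4 in this assay is 84%, expected to fall between 72% and 95%.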

Compound 4, largest response reached (reported as percent of maximum), in percent of the reference or control that the assay uses: 78%
Estimate against measurement, compound 4: 6 percentage points above, within the range that was stated.
By their numbers in this assay, from the lowest: compounds 4 and 1 (each within the scatter of the next); then compounds 2 and 3 (each within the scatter of the next).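

Methyl in place of hydrogen on the oxygen of the 3-carboxy-4-hydroxyphenyl group is a real loss in this assay, with a number 12.1 percentage points lower from compound 2 to compound 4 (beyond the scatter), so this aryl pattern does not hold up the response by itself and the group on that oxygen matters. Changing the aryl group from 5-carboxy-2-methoxyphenyl to 3-carboxy-4-methoxyphenyl does not separate the two methoxy compounds, with a number 1.2 percentage points lower from compound 1 to compound 4 (within the scatter), whereas 3-carboxy-4-methoxyphenyl in place of 5-carboxy-2-chlorophenyl gives a number 15.9 percentage points lower from compound 3 to compound 4 (beyond the scatter); across these four compounds the two methoxy-bearing members therefore form a lower pair, and none goes against that split. Nothing at hand accounts for the drop seen with the methoxy group.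

On these data alone, an amino or ethoxy group in place of the methoxy would show whether the loss extends beyond this one group, and that remains open. As far as these compounds go, all four compounds keep the carboxylic acid, so how a primary amide or a nitrile in its place would read on this aryl ring also remains open.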